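The compounds below may be only part of what the source reports. "The series", "measured", "known", "first", "only" and "open" are said of these compounds alone.

Measured in a functional assay on HeLa cells (Homo sapiens) for cytotoxicity; a higher number here means a weaker inhibitor of growth, a lower number a stronger inhibitor of growth:

Compound 1 `COc1ccc(NS(=O)(=O)c2c(F)c(F)c(F)c(F)c2Br)cc1`: 160 nM
Compound 2 `COc1ccc(NS(=O)(=O)c2c(F)c(F)cc(F)c2F)cc1`: > 50000 nM

Compound 2 reads > 50000 nM, and this is a limit of the assay, not a number. Its place on the scale is this: the limit of > 50000 nM in this assay, at which 1 of the 2 values shown sits.

Compound 3 `COc1ccc(NS(=O)(=O)c2c(F)c(F)c(F)c(F)c2F)cc1` differs from compound 2 in one place: fluoro in place of hydrogen on an aromatic carbon. Fluoro takes the place of hydrogen on an aromatic carbon, ortho to two fluoro groups, meta to two fluoro groups and para to a large group.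

Within the data shown here, no measured pair isolates this change. Compound 1 carries fluoro on that same carbon and gives 160 nM, so a large fall in this assay is expected for compound 3. The estimated change is an at least 410-fold lower number from compound 2 to compound 3 (2.61 log units; beyond the scatter), towards stronger growth inhibition. For compound 3 the estimated value is 120 nM, with an expected range of 30 nM to 600 nM.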

Compound 3, concentration for 50% growth inhibition: 99 nM
Estimate against measurement, compound 3: 1.2-fold (0.08 log units) above, within the range that was stated.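

In this assay, the change from hydrogen to fluoro on this carbon, para to a large group, gives an at least 500-fold lower number from compound 2 to compound 3 (2.70 log units; beyond the scatter), the first step measured at this position, and it is large. Compound 2 sits at a limit of the assay and not at a number, so that step has only a lower bound: the limit of > 50000 nM in this assay, at which 1 of the 3 values shown sits.

On a different carbon of the ring, the exchange of bromo for fluoro gives a 1.6-fold lower number from compound 1 to compound 3 (0.21 log units; within the scatter), which lies within the scatter, so compound 1 and compound 3, which both carry fluoro at the position in question, cannot be told apart.

The compounds shown hold only hydrogen and fluoro on this carbon, so it remains open whether chloro, methoxy or an amine there would keep the growth inhibition. Going by these compounds, it also remains open whether the same hydrogen-to-fluoro step would be as large on a different core.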